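The compounds below may be only part of what the source reports. "The series", "measured", "known", "first", "only" and "open" are said of these compounds alone.

Measured so far:
- compound 1, `CCc1cc(C(C)=O)c(O)cc1OCCCCC(C)(C)C#N`, 30%
- compound 2, `CCc1cc(C(C)=O)c(O)cc1OCCCCCC(C)(C)C#N`, 53%
- compound 3, `CCc1cc(C(C)=O)c(O)cc1OCCCC(C)(C)C(=O)O`, 43%

In an assay on isolated protein for binding affinity to leukotriene B4 receptor 1 (Homo sapiens), tested at 1 uM (on this read-out higher numbers stand for more inhibition at the one concentration tested (going by the name of the read-out) and lower numbers for less inhibition), compound 3 stands second highest of the three numbers. Its nearest neighbour is compound 2, and the step of a number 10 percentage points lower from compound 2 to compound 3 (within the scatter) lies within the scatter, so no order between these two can be read. Against compound 1 the step of a number 13 percentage points higher from compound 1 to compound 3 (beyond the scatter) is beyond the scatter, as is a number 23 percentage points higher from compound 1 to compound 2 (beyond the scatter).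

Compound 4, `CCc1cc(C(C)=O)c(O)cc1OCCCC(C)(C)C(N)=O`, is not yet measured. It differs from compound 3 in one place: amino in place of hydroxy on a carbonyl carbon. Among the measured compounds shown here, none of the measured steps exchanges a carboxy for a carbamoyl, so none bears directly on this change. What the measured compounds do show is that a chain ending in a nitrile, as in compound 2, reaches a number no lower than the carboxy of compound 3, so a neutral end group is not by itself a loss. For compound 4 a step of a number 3 percentage points lower from compound 3 to compound 4 (within the scatter) in this assay is therefore expected, within the scatter. The estimate for compound 4 is 40%, with a range from 20% to 60%.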

Compound 4, a percentage reported as inhibition, at one concentration (the size of the read-out at that concentration, not a potency): 51%
Estimate against measurement, compound 4: 11 percentage points below; the range from low to high includes it.
By their numbers in this assay, from the lowest: compound 1; then compounds 3, 4 and 2 (each within the scatter of the next).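

In this assay, amino in place of hydroxy on a carbonyl carbon gives a number 8 percentage points higher from compound 3 to compound 4 (within the scatter) and so no order can be read between these two, which means a carboxy is not needed at this place to reach this level of inhibition. Set against the 3-cyano-3-methylbutyl group, the 1-carbamoyl-1-methylethyl group gives a number 2 percentage points lower from compound 2 to compound 4 (within the scatter) with no readable difference, while against the 2-cyano-2-methylpropyl group it gives a number 21 percentage points higher from compound 1 to compound 4 (beyond the scatter) and that gap can be read. No measurement at hand says why these end groups read as they do.

The compounds shown leave open how a methyl ester or a methyl amide would read on this carbonyl carbon. They also leave open how the carbamoyl would read on a longer chain, a change that with the nitrile gave a number 23 percentage points higher from compound 1 to compound 2 (beyond the scatter) in this series.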